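The compounds below may be only part of what the source reports. "The series", "measured", "known", "first", "only" and "open" are said of these compounds alone.

Compound 1 `CCN1CCCC1CNC(=O)c1cc(NS(C)(=O)=O)c(C)cc1OC` gives 35.6 mg/kg in a functional assay on the whole organism for inhibition, with Mus musculus as the target; on this read-out higher numbers stand for an effect only at larger amounts of compound and lower numbers for an effect already at smaller amounts. Compound 2 `CCN1CCCC1CNC(=O)c1cc(NS(C)(=O)=O)c(Cl)cc1OC` gives 9.1 mg/kg in this assay. Compound 3 `CCN1CCCC1CNC(=O)c1cc(NS(N)(=O)=O)c(C)cc1OC` gives only a limit of > 50 mg/kg in this assay.

The change chloro in place of methyl on an aromatic carbon made a step of a 3.9-fold lower number from compound 1 to compound 2 (0.59 log units; beyond the scatter). The difference between the two cores is amino in place of methyl on a sulfonyl sulfur, and the step from compound 1 to compound 3 is only a floor, an at least 1.4-fold higher number from compound 1 to compound 3 (0.14 log units; that floor lies within the scatter), since it rests on (the limit of > 50 mg/kg in this assay, at which 1 of the 3 values shown sits).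

Compound 4 `CCN1CCCC1CNC(=O)c1cc(NS(N)(=O)=O)c(Cl)cc1OC` is not yet measured. Within the data shown here, it differs from compound 3 by chloro in place of methyl on an aromatic carbon; the surroundings differ from the first step in that the group is ortho to a sulfamoylamino group rather than ortho to a methanesulfonamido group, so this is the same kind of change, not the same change. The step is expected to be an at least 1.6-fold lower number from compound 3 to compound 4 (0.22 log units; that floor lies within the scatter), of about the size seen in a 3.9-fold lower number from compound 1 to compound 2 (0.59 log units; beyond the scatter), though the starting point for compound 3 is only a limit. Compound 4 is therefore estimated at 30 mg/kg, most likely between 12 mg/kg and 70 mg/kg, with a fair chance that this assay again reports only a limit.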

Compound 4, dose for half-maximal effect: > 50 mg/kg
Compound 4: a limit, no number; the forecaster's own chance of this, stated with the estimate: 35%; middle value at least 1.6-fold (0.22 log units) away from the limit.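

Compound 4 gives only a limit, > 50 mg/kg in this assay, and the step from chloro in place of methyl between compound 3 and compound 4 cannot be read. On the core of compound 2, amino in place of methyl on a sulfonyl sulfur gives an at least 5.4-fold higher number from compound 2 to compound 4 (0.73 log units; beyond the scatter). That step lies beyond the scatter whereas the floor on the core of compound 1 does not, yet this does not show that the change behaves differently on the two cores: the same change on two cores in this assay, an at least 1.4-fold higher number (0.14 log units; that floor lies within the scatter) from compound 1 to compound 3 and an at least 5.4-fold higher number (0.73 log units; beyond the scatter) from compound 2 to compound 4; the limit leaves it open whether they differ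

The compounds shown leave open how far compound 3 and compound 4 lie past their limits. They also leave open how an ethyl or a dimethylamino group on the sulfonyl sulfur, or a bromo in place of the chloro, would read.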